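Compound 3 to compound 4: exchanging the heteroaromatic group

The compounds below may be only part of what the source reports. "The series", "measured", "known", "first", "only" and "open" are said of these compounds alone.

In a functional assay on MCF7 cells (Homo sapiens) for antiproliferative activity, read by CellTiter-Glo, with a stated time of 5 days (on this read-out higher numbers stand for weaker inhibition and lower numbers for stronger inhibition), compound 1 (`O=C(O)/C=C/c1ccc(/C(=C(\c2ccccc2)C2CCC2)c2ccc3scnc3c2)cc1`) gives 16 nM, compound 2 (`N#Cc1cc(Cl)ccc1/C(=C(\c1ccc(/C=C/C(=O)O)cc1)c1ccc2scnc2c1)C1CCC1`) gives 0.9 nM and compound 3 (`O=C(O)/C=C/c1ccc(/C(=C(\c2ccc(C(F)(F)F)cc2Cl)C2CCC2)c2ccc3scnc3c2)cc1`) gives 2.6 nM. Compound 3 therefore has the second highest of the three numbers. All three measured steps concern the group on a double-bonded chain carbon bound to a double-bonded chain carbon and a saturated ring carbon: an 18-fold lower number from compound 1 to compound 2 (1.25 log units; beyond the scatter), a 6.2-fold lower number from compound 1 to compound 3 (0.79 log units; beyond the scatter) and a 2.9-fold higher number from compound 2 to compound 3 (0.46 log units; beyond the scatter).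

Compound 4 (`O=C(O)/C=C/c1ccc(/C(=C(\c2ccc(C(F)(F)F)cc2Cl)C2CCC2)c2ccc3nccn3c2)cc1`) leaves that group as in compound 3 and replaces 1,3-benzothiazol-5-yl instead: a group of 9 heavy atoms (7 carbon, 2 nitrogen; one five-membered aromatic ring with 2 hetero atoms, one six-membered aromatic ring with 1 hetero atom) in place of a group of 9 heavy atoms (7 carbon, 1 nitrogen, 1 sulfur; one five-membered aromatic ring with 2 hetero atoms, one six-membered aromatic ring of carbon only), on a double-bonded chain carbon bound to an aromatic carbon and a double-bonded chain carbon. For the measured compounds named here, none of the measured steps changes this place, so none gives a size for the new step, and the range must stay wide. The expectation rests on compound 3 at 2.6 nM, with no step beyond the scatter expected in either direction in this assay. The estimated step is a 1.3-fold higher number from compound 3 to compound 4 (0.13 log units; within the scatter). For compound 4 the estimate is 3.5 nM, with an expected range from 1 nM to 12 nM.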

Compound 4, half-maximal inhibitory concentration: 5.1 nM
Compound 4: middle estimate off by 1.5-fold (0.16 log units), on the low side; the range from low to high includes it.
By their numbers in this assay, from the lowest: compound 2; then compounds 3 and 4 (each within the scatter of the next); then compound 1.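

For the compounds shown here, this is the first reading at the place on a double-bonded chain carbon bound to an aromatic carbon and a double-bonded chain carbon, as all earlier steps changed only the other group. The exchange of 1,3-benzothiazol-5-yl for a group with no sulfur and a nitrogen in its six-membered ring gives a 2.0-fold higher number from compound 3 to compound 4 (0.29 log units; within the scatter) in this assay and so does not separate the two compounds, with the counts of heavy atoms and hydrogen-bond acceptors unchanged. No measurement here bears on the reason for this reading.

Going by these compounds, compound 2 and compound 4 differ in two places, so whether the exchange reads the same alongside 4-chloro-2-cyanophenyl stays open. Also open is how a group carrying an amine would read at this place, where only two groups are shown.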